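The source may report more compounds than this note shows. Statements on the series, on what has been measured and on what is new or still open speak of the compounds shown alone.

Going by the values given here, in a functional assay on cells (Homo sapiens) for cytotoxicity (on this read-out higher numbers stand for weaker inhibition and lower numbers for stronger inhibition), compound 2 `Nc1ccn([C@@H]2C=C(F)[C@H](CO)O2)c(=O)n1` gives 86900 nM, and this is the only actual number available so far. For compound 1 `Nc1nc(=O)n([C@H]2C=C(F)[C@@H](CO)O2)cc1F` the reading is > 100000 nM, which is a limit of this assay and not a number. Among the compounds with values here, compound 1 therefore gives no exact value against which compound 2 can be placed, and no step between measured compounds is available to serve as a guide.

The next compound to be tested is compound 3 `Nc1nc(=O)n([C@@H]2C=C(F)[C@H](CO)O2)cc1F`. It differs from compound 2 by fluoro in place of hydrogen on an aromatic carbon, ortho to an amino group: fluoro in place of hydrogen on an aromatic carbon. Within the data shown here, with no measured step to calibrate this change, only a modest shift is expected in this assay, perhaps toward a lower number, and a result within the usual scatter of compound 2 would be no surprise. The estimated step is a 1.7-fold lower number from compound 2 to compound 3 (0.24 log units; within the scatter). The reading could also reach the limit of the assay, as it did for compound 1 at > 100000 nM. Compound 3 is expected to read 50000 nM, with an estimated range from 12000 nM to 100000 nM.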

Compound 3, half-maximal inhibitory concentration: > 100000 nM
Compound 3 gave a limit, no number; the forecaster's own chance of this, stated with the estimate: 40%; middle value at least 2.0-fold (0.30 log units) away from the limit.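

In this assay, going by these compounds alone, fluoro in place of hydrogen on an aromatic carbon, ortho to an amino group, gives an at least 1.1-fold higher number from compound 2 to compound 3 (0.06 log units; that floor lies within the scatter), so this change is the first step at this position that can be read, and it shows no move towards stronger inhibition. Compound 3 reads > 100000 nM, which is a limit of the assay and not a number. Only a floor is known for this step, and the step between compounds 1 and 3 cannot be read at all, because both readings rest on the same limit: the limit of > 100000 nM in this assay, at which 2 of the 3 values shown sit.

On these data alone, whether the drawn configuration matters in this assay stays open, since compounds 1 and 3 both give limits and the one thing that sets them apart is their configuration: the fact that compounds 1 and 3 differ only in the configuration as drawn Also open is whether chloro, a methyl group or a hydroxyl group on the same aromatic carbon would give a number that can be read against compound 2, and how far the true value of compound 3 lies from that of compound 2.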